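Furan-2-yl in Place of 2-Nitrophenyl: Expectation for Compound 4

The compounds below may be only part of what the source reports. "The series", "measured", "known", "first", "only" and "open" are said of these compounds alone.

Measured in a functional assay on OVCAR cells (Homo sapiens) for cytotoxicity, read by sulforhodamine B assay, with a stated time of 48 h; a higher number here means a weaker inhibitor, a lower number a stronger inhibitor:
- compound 1, `CC(=O)N1N=C(c2cccc3ccccc23)CC1c1ccccc1`, gives 7820 nM
- compound 2, `O=CCN1N=C(c2ccc3ccccc3c2)CC1c1cccc([N+](=O)[O-])c1`, gives 3390 nM
- compound 3, `O=CCN1N=C(c2ccc3ccccc3c2)CC1c1ccccc1[N+](=O)[O-]`, gives 3480 nM

Compound 3 stands second highest of the three numbers in this assay. For the measured compounds named here, compound 2 lies closest to it, and the one measured step, a 1.0-fold higher number from compound 2 to compound 3 (0.01 log units; within the scatter), is within the scatter. Compound 1 is furthest, with a higher number beyond the scatter.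

Compound 4, `O=CCN1N=C(c2ccc3ccccc3c2)CC1c1ccco1`, differs from compound 3 by furan-2-yl in place of 2-nitrophenyl on a saturated ring carbon. Going by the values given here, no measured pair exchanges the 2-nitrophenyl for another ring, so no step bears directly on this change; the only step, which moved the nitro group, was within the scatter. Compound 4 is therefore expected to show no step beyond the scatter in this assay, a 1.1-fold higher number from compound 3 to compound 4 (0.06 log units; within the scatter). The estimate for compound 4 is 4000 nM, with a range from 1500 nM to 11000 nM.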

Compound 4, half-maximal inhibitory concentration: 18000 nM
Compound 4: middle estimate off by 4.5-fold (0.65 log units), on the low side, and the stated range ends below it.
By their numbers in this assay, from the lowest: compounds 2 and 3 (each within the scatter of the next); then compound 1; then compound 4.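

In this assay, the saturated ring carbon turns out not to be indifferent to what it carries: moving the nitro group changed little, but exchanging the whole ring does, with a 5.2-fold higher number from compound 3 to compound 4 (0.71 log units; beyond the scatter) and a 5.3-fold higher number from compound 2 to compound 4 (0.73 log units; beyond the scatter). Both nitrophenyl compounds thus stand apart from the furan-2-yl compound by a similar step. Nothing measured here accounts for this weakening. The compounds shown leave open whether the step follows from the nitro group leaving or from the five-membered ring entering. A plain phenyl or an aminophenyl on this carbon would separate the two.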